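The compounds below may be only part of what the source reports. "The series", "measured", "known", "first", "only" and "open" are said of these compounds alone.

Compound 1 `COC(=O)CCCCCN1C(=O)/C(=C2/C(=O)N(Cc3ccc(C)cc3)c3ccccc32)SC1=S` and compound 2 `CCCCCCOc1ccc(/C=C2\SC(=S)N(CCCC(=O)O)C2=O)cc1` were tested in an assay for inhibition of histone acetyltransferase KAT2B (Homo sapiens), read by TR-FRET, with a stated time of 10 min, tested at 50 uM; a higher number here means more inhibition at the concentration tested (going by the name of the read-out), a lower number less inhibition. Compound 1 gives 8% in this assay, and compound 2 gives 8%. Compound 3 `O=C(O)CCCCCN1C(=O)/C(=C/c2ccc(-c3ccccc3)cc2)SC1=S` returns only a limit, < 5%, so no number is known for it. It stands at the limit of < 5% in this assay, at which 1 of the 3 values shown sits. All three results are small, and none of them is separated from the others beyond the usual scatter. Compound 4 `CN(C)c1ccc(/C=C2\SC(=S)N(CCCCCC(=O)O)C2=O)cc1` has not yet been measured; compared with compound 3 it carries dimethylamino in place of phenyl on an aromatic carbon. Among the compounds with values here, no step between measured compounds is available here, so the expected step in this assay is a number at least 2 percentage points higher from compound 3 to compound 4 (that floor lies within the scatter), none beyond the scatter. Compound 4 is therefore estimated at 7% in this assay, with a range from 0% to 20%.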

Compound 4, a percentage reported as inhibition, at one concentration (the size of the read-out at that concentration, not a potency): < 5%
Compound 4 ended at the assay's limit (the forecaster's own chance of this, stated with the estimate: 40%); at least 2 percentage points between middle value and limit.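

Compound 3 and compound 4 both end at a limit rather than a number, so no step can be read between them: the limit of < 5% in this assay, at which 2 of the 4 values shown sit.

Left open is whether phenyl and dimethylamino differ at all in this assay.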